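This account rests on a few compounds, and the source may have more. Where it says the series, first, only, none or still open, it means among the compounds named here.

Of the compounds shown here, two with the same core have been tested so far in a functional assay on PC-3 cells (Homo sapiens) for cytotoxicity, read by sulforhodamine B assay, with a stated time of 5 days; a lower number here means a stronger inhibitor, a higher number a weaker inhibitor. Compound 1 `O=C(CCCCCc1ccccc1)N[C@H]1CCOC1=O` gives > 100000 nM. That figure is a limit of the measurement and not a number.

For the measured compounds named here, compound 2 `O=C(CCCCCCCc1ccccc1)N[C@H]1CCOC1=O` gives 85000 nM, the only true number available, so it is the sole firm point of reference here. The next compound, compound 3 `O=C(CCCCCCc1ccccc1)N[C@H]1CCOC1=O`, differs from compound 2 at one place: phenyl in place of benzyl on a saturated chain carbon, six bonds along the chain from a carbonyl carbon. In words, it has phenyl in place of benzyl on a saturated chain carbon, six bonds along the chain from a carbonyl carbon.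

Going by the values given here, no measured step between two numbers shows how large such a change might be. The expectation is therefore no shift beyond the usual scatter, in either direction, and the estimated move is a 1.1-fold higher number from compound 2 to compound 3 (0.05 log units; within the scatter). Compound 3 is expected to give about 95000 nM, with an estimated range from 55000 nM to 160000 nM.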

Compound 3, half-maximal inhibitory concentration: > 100000 nM
Compound 3 was reported as a limit; the forecaster's own chance of this, stated with the estimate: 50%; middle value at least 1.0-fold (0.02 log units) from the limit.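

In this assay, for the compounds shown here, the first readable look at this change, phenyl in place of benzyl on a saturated chain carbon, gives an at least 1.1-fold higher number from compound 2 to compound 3 (0.07 log units; that floor lies within the scatter), so it shows no sign of a stronger inhibitor. Going by these compounds, compound 3 gives > 100000 nM, which is a limit and not a number, so the true size of this step stays unknown. The step from compound 1 to compound 3 cannot be read because both compounds stand at the same limit: the limit of > 100000 nM in this assay, at which 2 of the 3 values shown sit.

On these data alone, how much higher the true number of compound 3 may lie than that of compound 2 remains open. Also open, as far as these compounds go, is whether a longer chain, or an amine or a carboxylic acid in place of the phenyl group, would give a number clearly lower than that of compound 2.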